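This account rests on a few compounds, and the source may have more. Where it says the series, first, only, none or still open, it means among the compounds named here.

- compound 1 `O=C(Nc1cc2ncncc2cc1OCc1ccc(F)cc1)Nc1cccc2ccccc12`: 4500 nM
- compound 2 `O=C(Nc1ccccc1F)Nc1cc2ncncc2cc1OCc1ccccc1F`: 3600 nM

In a functional assay on GBM2 cells (Homo sapiens) for antiproliferative activity, read by WST assay, with a stated time of 72 h (a lower number here means a stronger inhibitor, a higher number a weaker inhibitor), compound 1 gives 4500 nM and compound 2 gives 3600 nM. These two values lie within the usual scatter of each other, so compound 1 cannot be ranked against compound 2.

Compound 3 `O=C(Nc1cc2ncncc2cc1OCc1cccc(F)c1)Nc1cccc2ccccc12` has not been measured yet. Among the measured compounds shown here, it keeps the core of compound 1, and the only change is 3-fluorophenyl in place of 4-fluorophenyl on a saturated chain carbon bound to an oxygen on an aromatic ring.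

For the measured compounds named here, no two measured compounds differ in just one place, so the data offer no direct guide to this change. The expectation therefore rests on compound 1 at 4500 nM, with no step beyond the scatter and no favoured direction in this assay. The estimated step is a 1.1-fold lower number from compound 1 to compound 3 (0.03 log units; within the scatter). Compound 3 is expected at 4200 nM, within an estimated range of 1800 nM to 10000 nM.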

Compound 3, half-maximal inhibitory concentration: 1400 nM
Beside the measured number, compound 3's estimate is 3.0-fold (0.48 log units) above it; the measured number lies below the stated range.
By their numbers in this assay, from the lowest: compound 3; then compounds 2 and 1 (each within the scatter of the next).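

Replacing (4-fluorobenzyl)oxy with (3-fluorobenzyl)oxy, with the same atoms joined differently, gives a 3.2-fold lower number from compound 1 to compound 3 (0.51 log units; beyond the scatter) in this assay and takes the number beyond the usual scatter. This shows that the activity responds to where the fluorine sits on this ring, even though the atoms present do not change, something compounds 1 and 2 could not show, since they differ in more than one place. No measurement here accounts for the step.

On these data alone, it remains open whether a chlorine atom or a methoxy group in place of the fluorine of the 3-fluorobenzyl group would give a lower or a higher number. Also open, as far as these compounds go, is whether the same change would give a similar step in compound 2, which differs from compound 1 in more than this one group.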